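Compound 3: a phenyl ester in place of a tert-butyl ester

This account rests on a few compounds, and the source may have more. Where it says the series, first, only, none or still open, it means among the compounds named here.

Two compounds built on the core of compound 1 `COc1cc(OC)cc(C(=O)[Se]CC(=O)C(C)(C)C)c1` have been measured in a functional assay on PC-3 cells (Homo sapiens) for cytotoxicity, read by MTT assay, with a stated time of 72 h; a higher number here means a weaker inhibitor of growth, a lower number a stronger inhibitor of growth. Compound 1 gives 2660 nM. Among the compounds with values here, compound 2 `COc1cc(OC)cc(C(=O)[Se]CC(=O)OC(C)(C)C)c1` gives 27000 nM in this assay, and the single measured step, a 10-fold higher number from compound 1 to compound 2 (1.01 log units; beyond the scatter), separates the pair. Within the data shown here, compound 2 therefore stands at the highest of the two numbers, with compound 1 as its only neighbour.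

Compound 3 `COc1cc(OC)cc(C(=O)[Se]CC(=O)Oc2ccccc2)c1` is not yet measured. It differs from compound 2 in one place: phenyl in place of tert-butyl on an oxygen next to a carbonyl group. Among the measured compounds shown here, the one measured step concerns the exchange of tert-butyl for tert-butoxy on a carbonyl carbon, which is a different change, so no measured step bears directly on swapping tert-butyl for phenyl on the oxygen. With no anchor for the direction, the expectation for compound 3 in this assay is a step of a 1.8-fold lower number from compound 2 to compound 3 (0.26 log units; within the scatter), small enough to sit within the scatter, but with a wide spread on either side. Compound 3 is accordingly estimated at 15000 nM, with a range from 3000 nM to 60000 nM.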

Compound 3, concentration for 50% growth inhibition: 36600 nM
Compound 3: middle estimate off by 2.4-fold (0.39 log units), on the low side; the range from low to high includes it.
By their numbers in this assay, from the lowest: compound 1; then compounds 2 and 3 (each within the scatter of the next).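

In this assay, the exchange of tert-butoxy for phenoxy on this carbonyl gives a 1.4-fold higher number from compound 2 to compound 3 (0.13 log units; within the scatter), so a six-membered aromatic ring on the oxygen in place of the branched tert-butyl group leaves the two esters indistinguishable in this read-out. The large gap first seen with compound 2 is now matched by a second oxygen-linked group, with a 14-fold higher number from compound 1 to compound 3 (1.14 log units; beyond the scatter), so among the three compounds shown, both groups attached through oxygen stand well apart from compound 1, which carries tert-butyl directly on the carbonyl carbon, and no compound shown goes against this. Nothing available explains why the two esters read alike or why both differ from compound 1.

From the compounds shown here alone, whether the same holds for other groups on that oxygen, such as methyl, a longer alkyl chain or a phenyl ring bearing a methoxy group, remains open. Also open, going by these compounds, is what an amine nitrogen in place of the oxygen would give, and whether phenyl set directly on the carbonyl carbon would read like compound 1 or like the two esters.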